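Compound 3: a bromophenyl enters where an acetyl once stood

A few compounds are considered here, and "the series" means these few. Any claim that something is new, unique, unknown or untested is made for them only; others in the source may bear on it.

For the measured compounds named here, compound 1 `O=C(CCCCC1CCSS1)NCc1cn(CCCOc2ccc3ccc(=O)oc3c2)nn1` holds the higher of the two numbers measured so far, though the gap to its only neighbour is within the scatter. In a functional assay on PC-12 cells (Rattus norvegicus) for cytotoxicity, read by MTT assay, with stated times of 3 h and 2 h, tested at 1 uM (a lower number here means a weaker effect, a higher number a stronger effect of the compound at the concentration tested), compound 1 gives 37.2%. Compound 2 `CC(=O)c1cc2ccc(OCCCn3cc(CNC(=O)CCCCC4CCSS4)nn3)cc2oc1=O` carries an acetyl in place of hydrogen on an aromatic carbon of the shared core; in this assay compound 2 gives 35.5%, and the step of a number 1.7 percentage points lower from compound 1 to compound 2 (within the scatter) lies within the scatter. Compound 3 `O=C(CCCCC1CCSS1)NCc1cn(CCCOc2ccc3cc(-c4ccc(Br)cc4)c(=O)oc3c2)nn1` has not yet been measured in this assay. It differs from compound 1 by 4-bromophenyl in place of hydrogen on an aromatic carbon. Going by the values given here, the one measured step that bears on this change, a number 1.7 percentage points lower from compound 1 to compound 2 (within the scatter), placed another group on an aromatic carbon of the same core and stayed within the scatter. A step of similar size, a number 0.2 percentage points lower from compound 1 to compound 3 (within the scatter), is therefore expected, in no direction beyond the scatter. Compound 3 is estimated to give 37% in this assay, between 25% and 49%.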

Compound 3, a percentage reported as activity, at one concentration (the size of the read-out at that concentration, not a potency): 42.8%
Compound 3: the middle estimate sits 5.8 percentage points below what was measured; measured number inside the range.
By their numbers in this assay, from the lowest: compounds 2, 1 and 3 (each within the scatter of the next).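

Placing 4-bromophenyl on this aromatic carbon gives a number 5.6 percentage points higher from compound 1 to compound 3 (within the scatter), and putting it in place of the acetyl gives a number 7.3 percentage points higher from compound 2 to compound 3 (within the scatter). For the compounds shown here, this carbon, two atoms from the ring oxygen, has thus now carried a hydrogen, an acetyl and a group with a whole six-membered aromatic ring, and in this assay no step among the three compounds leaves the scatter, so an added aromatic ring here brings no change that can be told from scatter. No measurement is at hand that would account for these numbers.

The compounds shown leave open whether the bromine matters, as plain phenyl does not appear among them. They also leave open how an amine or a carboxylic acid on this same carbon would read in this assay.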